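A nitro group added to the methoxy analogue of a benzanilide

The compounds below may be only part of what the source reports. "The series", "measured", "known", "first", "only" and "open" are said of these compounds alone.

This account concerns four benzanilides that share one core and differ at two places. Compound 1 `Cc1cc(NC(=O)c2ccc(Cl)cc2)ccc1NS(=O)(=O)C(F)(F)F` is the parent; in an ADME assay on RAW264.7 cells (Mus musculus) for cytotoxicity, read by MTT assay, with a stated time of 48 h (on this read-out higher numbers stand for weaker inhibition and lower numbers for stronger inhibition), compound 1 gives 35400 nM. Compound 2 `Cc1cc(NC(=O)c2ccc(Cl)c([N+](=O)[O-])c2)ccc1NS(=O)(=O)C(F)(F)F` carries the change (nitro in place of hydrogen on an aromatic carbon), and in this assay compound 2 gives 89800 nM, which is a 2.5-fold higher number from compound 1 to compound 2 (0.40 log units; beyond the scatter). Compound 3 `COc1cc(NC(=O)c2ccc(Cl)cc2)ccc1NS(=O)(=O)C(F)(F)F` carries instead the change (methoxy in place of methyl on an aromatic carbon), and in this assay compound 3 gives 108000 nM, which is a 3.1-fold higher number from compound 1 to compound 3 (0.48 log units; beyond the scatter). The values of compound 2 and compound 3 lie within the scatter of one another, so nothing separates those two.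

Compound 4 `COc1cc(NC(=O)c2ccc(Cl)c([N+](=O)[O-])c2)ccc1NS(=O)(=O)C(F)(F)F` has not yet been measured. It differs from compound 3 by nitro in place of hydrogen on an aromatic carbon, which is the same change that was made from compound 1 to compound 2, since the two place descriptions agree word for word. That change was made only once among the measured compounds, so its size rests on a single step. Taking compound 3 as the start, the step to compound 4 in this assay is expected to be a 2.3-fold higher number from compound 3 to compound 4 (0.36 log units; beyond the scatter), on the grounds that the earlier step was a 2.5-fold higher number from compound 1 to compound 2 (0.40 log units; beyond the scatter). Compound 4 is accordingly estimated at 250000 nM, with a likely range from 110000 nM to 600000 nM. Because compound 3 already gives 108000 nM, the number expected for compound 4 would be the weakest inhibition in this series, and that expectation rests on one step alone.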

Compound 4, half-maximal inhibitory concentration: > 250000 nM
Compound 4 gave a limit, no number; the forecaster's own chance of this, stated with the estimate: 35%; the middle value lies on the limit itself.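

In this assay compound 4 gives > 250000 nM and this is a limit of the assay, not a number. Nitro in place of hydrogen on an aromatic carbon moves the number the same way on both cores, with an at least 2.3-fold higher number from compound 3 to compound 4 (0.36 log units; beyond the scatter) and this shows that the direction of the change carries over from the core of compound 1 to the methoxy core, though it gives no size for the second step that could be matched against the first: the same change on two cores in this assay, a 2.5-fold higher number (0.40 log units; beyond the scatter) from compound 1 to compound 2 and an at least 2.3-fold higher number (0.36 log units; beyond the scatter) from compound 3 to compound 4; the limit leaves it open whether they differ. Methoxy in place of methyl on an aromatic carbon likewise keeps its direction once the nitro group is present, with an at least 2.7-fold higher number from compound 2 to compound 4 (0.44 log units; beyond the scatter) and here too the carry-over is shown in direction only, not in size: the same change on two cores in this assay, a 3.1-fold higher number (0.48 log units; beyond the scatter) from compound 1 to compound 3 and an at least 2.7-fold higher number (0.44 log units; beyond the scatter) from compound 2 to compound 4; the limit leaves it open whether they differ.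

The compounds shown leave open how large the nitro step on the methoxy core really is, and so whether the two changes simply add or whether one grows or shrinks in the presence of the other. On these data alone, it also stays open whether an amine or a carboxylic acid in place of the nitro group, or a longer chain in place of the methoxy group, would move the number in the same way.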